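The compounds below may be only part of what the source reports. "The series", "measured", "known", "first", "only" and "open" are said of these compounds alone.

Of the compounds shown here, two have been measured so far. Compound 1 `CC(C)C[C@H](N)c1cc(C(F)(F)F)ccc1N1CCN(C(=O)COc2ccc3ccccc3c2)CC1` carries a trifluoromethyl group on its core and an amide bearing a (naphthalen-2-yl)oxy)methyl group. In an assay on HEK293 cells for displacement of a labelled ligand from Melanocortin receptor 4 (Homo sapiens) (a higher number here means a weaker inhibitor, a lower number a stronger inhibitor), compound 1 gives 2000 nM. Compound 2 `CC(C)C[C@H](N)c1ccccc1N1CCN(C(=O)[C@H](C)Cc2ccc(Cl)cc2F)CC1` lacks the trifluoromethyl group and carries a different amide; in this assay compound 2 gives 67 nM. Of the two numbers, compound 1 stands at the higher one, and its gap to compound 2 lies beyond the usual scatter, so compound 1 is the weaker inhibitor of the pair.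

Compound 3 `COc1ccc(OCC(=O)N2CCN(c3ccc(C(F)(F)F)cc3[C@@H](N)CC(C)C)CC2)cc1` differs from compound 1 in one place: 4-methoxyphenyl in place of naphthalen-2-yl on an oxygen on a saturated carbon. Among the measured compounds shown here, no pair of measured compounds differs in this way, so there is no measured step to lean on, and the size of the step from compound 1 to compound 3 can only be guessed. With a flat, smaller aromatic group in place of the fused pair of rings, the change in this assay is expected to be modest and could run in either direction. For compound 3 a value of 2500 nM is estimated, within a range of 800 nM to 8000 nM, meaning an expected step of a 1.3-fold higher number from compound 1 to compound 3 (0.10 log units; within the scatter).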

Compound 3, inhibition constant: 3800 nM
Compound 3: middle estimate off by 1.5-fold (0.18 log units), on the low side, and the stated range covers the measured number.
By their numbers in this assay, from the lowest: compound 2; then compounds 1 and 3 (each within the scatter of the next).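

In this assay, putting 4-methoxyphenyl in place of naphthalen-2-yl on an oxygen on a saturated carbon gives a 1.9-fold higher number from compound 1 to compound 3 (0.28 log units; within the scatter) and leaves the two compounds indistinguishable in this measurement. Among the compounds shown here, this is the first direct reading at this position, where the shared core and the amide link are held constant and only the group on the oxygen differs. For this pair, going from two six-membered aromatic rings of carbon only to one such ring, with a methoxy group and one hydrogen-bond acceptor added, leaves no difference that can be told from repeat-measurement noise, and nothing measured here gives a reason for this result.

The compounds shown leave open whether this insensitivity holds for very different groups at the same place, such as a phenyl ring carrying an amine or a carboxylic acid, or a longer chain in place of the methoxy group. For the compounds shown here, they also contain no pair that differs in the trifluoromethyl group alone, and the share of that group in these numbers stays open.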